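The compounds below may be only part of what the source reports. "The series", "measured", "known", "first", "only" and "open" are said of these compounds alone.

Measured compounds and their largest responses:

Compound 1, `O=C(O)CCc1ccc(NCc2ccc(-c3ccccc3)cc2)cc1`: 111%
Compound 2, `O=C(O)CCc1ccc(NCc2ccc(Cl)s2)cc1`: 143%
Compound 3, `Cc1ccc(CNc2ccc(CCC(=O)O)cc2)cc1`: 152%

These three compounds share a common core and differ only in the group attached to the benzylic part of the molecule. In a functional assay on CHO cells for agonist activity at Free fatty acid receptor 1 (Homo sapiens), read by reporter gene assay (on this read-out higher numbers stand for larger maximal responses and lower numbers for smaller maximal responses), compound 3 stands highest of the three numbers, although its lead over compound 2 lies within the scatter, so the two cannot be ranked against each other; only the gap to compound 1 is beyond the scatter.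

Among the measured compounds shown here, the one step that can be measured directly, a number 41 percentage points higher from compound 1 to compound 3 (beyond the scatter), shows that replacing a phenyl with a methyl at this position raised the maximal response by a large amount. Compound 4, `O=C(O)CCc1ccc(NCc2ccccc2)cc1`, goes one step further in the same direction of shrinking the group: hydrogen in place of methyl on an aromatic carbon. For the measured compounds named here, no measured pair covers this exact change, so the expectation rests on the single step from phenyl to methyl, which does not necessarily carry on once the methyl is gone. Compound 4 is therefore expected to stay roughly level with compound 3, with a step of a number 12 percentage points lower from compound 3 to compound 4 (beyond the scatter) that is not expected to exceed the scatter. The estimated value for compound 4 is 140%, within a range from 115% to 165%.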

Compound 4, largest response reached (reported as percent of maximum), in percent of the reference or control that the assay uses: 144%
The estimate for compound 4 lay 4 percentage points below the measured number; low and high end bracket the measured number.
By their numbers in this assay, from the lowest: compound 1; then compounds 2, 4 and 3 (each within the scatter of the next).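

In this assay, the step of a number 8 percentage points lower from compound 3 to compound 4 (within the scatter) shows that the methyl can be removed from this position without a clear change, so a bare hydrogen on this aromatic carbon serves as well as a methyl. The step of a number 33 percentage points higher from compound 1 to compound 4 (beyond the scatter) confirms the earlier finding from the other direction: with either small substituent the response stands clearly above that of the phenyl-bearing compound 1, so the lower number goes with the added phenyl and not with the loss of the methyl. The step of a number 1 percentage points higher from compound 2 to compound 4 (within the scatter) adds that phenyl in place of 5-chlorothiophen-2-yl on the chain carbon leaves the two compounds level within the scatter.

The compounds shown leave open how a group of a different kind at this position, such as an ethyl, a methoxy or an amine, would compare with hydrogen and methyl. Nothing available here explains why the phenyl goes with the smaller maximal response.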